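A Chlorine Moves Round the Ring: Compound 3 Expected

The source may report more compounds than this note shows. Statements on the series, on what has been measured and on what is new or still open speak of the compounds shown alone.

Of the compounds shown here, two sharing one core have been tested in a functional assay, with a stated time of 150 min; on this read-out lower numbers stand for stronger inhibition and higher numbers for weaker inhibition. Compound 1 `CCOC(=O)c1cnn(-c2nc(-c3ccccc3Cl)c(C#N)c(=O)n2C)c1N` gives 93 ug/mL. Compound 2 `CCOC(=O)c1cnn(-c2nc(-c3cccc(O)c3O)c(C#N)c(=O)n2C)c1N` gives 58 ug/mL. The only difference between them is the aryl group on the core, and the step of a 1.6-fold lower number from compound 1 to compound 2 (0.21 log units; within the scatter) is too small to separate the two; neither can be called the stronger inhibitor.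

Compound 3 `CCOC(=O)c1cnn(-c2nc(-c3ccc(Cl)cc3)c(C#N)c(=O)n2C)c1N` returns to a chlorine-bearing aryl group, but with the chlorine in a different position: 4-chlorophenyl in place of 2,3-dihydroxyphenyl on an aromatic carbon. Among the measured compounds shown here, the one measured step that bears on this, from compound 1 to compound 2, swapped a chlorophenyl for the dihydroxyphenyl and stayed within the scatter. Reversing that kind of change is therefore expected to stay within the scatter as well, landing near the two known numbers. For compound 3 the expected result in this assay is 80 ug/mL, with a likely range from 40 ug/mL to 160 ug/mL, which means an estimated step of a 1.4-fold higher number from compound 2 to compound 3 (0.14 log units; within the scatter).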

Compound 3, half-maximal inhibitory concentration: 87 ug/mL
For compound 3 the middle estimate is 1.1-fold (0.04 log units) below the measured one, and the stated range covers the measured number.
By their numbers in this assay, from the lowest: compounds 2, 3 and 1 (each within the scatter of the next).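

In this assay the place of the chlorine on the aryl group can now be read directly: 4-chlorophenyl in place of 2-chlorophenyl gives a 1.1-fold lower number from compound 1 to compound 3 (0.03 log units; within the scatter) and the two chlorophenyl compounds cannot be told apart. 4-Chlorophenyl in place of 2,3-dihydroxyphenyl gives a 1.5-fold higher number from compound 2 to compound 3 (0.18 log units; within the scatter) as well, so a group with no hydrogen-bond donors or acceptors cannot be separated here from one that has both. Nothing available explains why these three aryl groups read alike.

On these data alone, all three compounds carry a six-membered aromatic ring of carbon at this position, so the effect of an aminophenyl or carboxyphenyl group, or of a longer chain in place of the ring, remains open. Also open, as far as these compounds go, is whether any change at this position can move the number beyond the scatter.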